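Swapping the Aryl Group: From Naphthalene to Pyridine

A few compounds are considered here, and "the series" means these few. Any claim that something is new, unique, unknown or untested is made for them only; others in the source may bear on it.

Compound 1, `COc1cncc(-c2ccnc3c2c(C(C)C)nn3-c2ccc(C(N)=O)c(N[C@H]3CC[C@H](O)CC3)c2)c1`: 451 nM in a functional assay on SK-BR-3 cells (Homo sapiens) for inhibition, read by CellTiter-Glo, with a stated time of 72 h; a lower number here means a stronger inhibitor, a higher number a weaker inhibitor.
Compound 2, `CC(C)c1nn(-c2ccc(C(N)=O)c(N[C@H]3CC[C@H](O)CC3)c2)c2nccc(-c3ccoc3)c12`: > 10000 nM, a limit of the assay.
Compound 3, `CC(C)c1nn(-c2ccc(C(N)=O)c(N[C@H]3CC[C@H](O)CC3)c2)c2nccc(-c3ccc4ccccc4c3)c12`: > 10000 nM, a limit of the assay.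

Compound 3 thus stands at the limit of > 10000 nM in this assay, at which 2 of the 3 values shown sit, so its true number is not known. Compound 4, `CC(C)c1nn(-c2ccc(C(N)=O)c(N[C@H]3CC[C@H](O)CC3)c2)c2nccc(-c3cccnc3)c12`, differs from it by pyridin-3-yl in place of naphthalen-2-yl on an aromatic carbon. Among the compounds with values here, the steps that bear on this are an at least 22-fold higher number from compound 1 to compound 3 (1.34 log units; beyond the scatter) and an at least 22-fold higher number from compound 1 to compound 2 (1.34 log units; beyond the scatter), both large, whereas a step that the two limits leave unreadable from compound 2 to compound 3. Since the pyridin-3-yl of compound 4 is close to the 5-methoxypyridin-3-yl of compound 1 (451 nM), lacking only the methoxy group, compound 4 is expected to come back toward a readable number: an at least 8.3-fold lower number from compound 3 to compound 4 (0.92 log units; beyond the scatter). Compound 4 is therefore estimated at 1200 nM, within 300 nM to 6000 nM.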

Compound 4, half-maximal inhibitory concentration: 464 nM
The estimate for compound 4 lay 2.6-fold (0.41 log units) above the measured number; the measured number falls inside the stated range.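

The change to pyridin-3-yl gives an at least 21-fold lower number from compound 3 to compound 4 (1.33 log units; beyond the scatter) and an at least 21-fold lower number from compound 2 to compound 4 (1.33 log units; beyond the scatter) in this assay and each step starts from a limit, not a number. Hydrogen in place of methoxy gives a 1.0-fold higher number from compound 1 to compound 4 (0.01 log units; within the scatter) and so makes no readable difference on the pyridine ring. Of the four compounds, only the two with a pyridine ring give readable numbers.

From the compounds shown here alone, what a plain phenyl ring would give here stays open, so the ring nitrogen cannot be separated from ring size. Going by these compounds, the effect of an amine in place of the methoxy group is also open.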